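The source may report more compounds than this note shows. Statements on the series, on what has been measured and on what is new or still open speak of the compounds shown alone.

Measured compounds:
Compound 1 `Cc1ccc(-n2cc(-c3ccccc3NS(=O)(=O)c3c[nH]c(=O)[nH]c3=O)nn2)cc1` — in an ADME assay on L02 cells (Homo sapiens) for cytotoxicity, read by MTT assay, with a stated time of 24 h (a higher number here means that more compound is tolerated, a lower number that less compound is tolerated), compound 1 gives > 100000 nM.
Compound 2 `Cc1ccc(-n2cc(-c3cccc(NS(=O)(=O)c4c[nH]c(=O)[nH]c4=O)c3)nn2)cc1` — in this assay compound 2 gives 23100 nM.
Compound 3 `O=c1[nH]cc(S(=O)(=O)Nc2ccc(-c3cn(-c4ccccc4)nn3)cc2)c(=O)[nH]1` — in this assay compound 3 is reported as "not toxic" (no number reported).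

The value for compound 1 is a limit of the assay and not a number; it sits at the limit of > 100000 nM in this assay, at which 1 of the 3 values shown sits. Compound 2 is the only one of the three with a numerical half-maximal cytotoxic concentration. Compound 3 stands without a number: it is described only as not toxic, so where it falls relative to compound 2 cannot be read from the figures shown, beyond the qualitative statement.

Compound 4 `O=c1[nH]cc(S(=O)(=O)Nc2ccc(-c3cn(-c4ccc(F)cc4)nn3)cc2)c(=O)[nH]1` differs from compound 3 by fluoro in place of hydrogen on an aromatic carbon. Among the compounds with values here, no pair of measured compounds differs in a single place, so there is no measured step to lean on. For so small a change he expects no shift in this assay beyond the usual scatter, in either direction, and a fair chance that only a limit is reported. Compound 4 is accordingly estimated at 100000 nM, within 20000 nM to 400000 nM.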

Compound 4, half-maximal cytotoxic concentration: "not toxic" (no number reported)
Compound 4: no number reported; the estimate stays without a comparison.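

Compound 3 and compound 4 are both reported in this assay only as not toxic, without a number, so no step can be read from compound 3 to compound 4. Going by these compounds, what the fluoro in place of hydrogen does to tolerated concentration in this assay stays open.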